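Moving the Chlorine Around a Benzyl Group

A few compounds are considered here, and "the series" means these few. Any claim that something is new, unique, unknown or untested is made for them only; others in the source may bear on it.

Measured compounds:
compound 1 `COc1ccc(C2N=C(SCc3ccccc3Cl)NC(C)=C2C(=O)Nc2ccc(F)cc2)cc1OC` gives 30.3%
compound 2 `COc1ccc(C2N=C(SCc3cccc(Cl)c3)NC(C)=C2C(=O)Nc2ccc(F)cc2)cc1OC` gives 14.9%
compound 3 `CC1=C(C(=O)Nc2ccc(F)cc2)C(c2ccc([N+](=O)[O-])cc2)N=C(SCc2ccccc2Cl)N1` gives 15.9%

All three were tested in a functional assay on the whole organism (artery, strain albino) with Rattus norvegicus as the target, with a stated time of 240 min, at a dose of 10 mg/kg by the oral route; on this read-out lower numbers stand for less inhibition and higher numbers for more inhibition at the one dose given (going by the name of the read-out). Compound 1 and compound 2 differ in one place, (3-chlorophenyl in place of 2-chlorophenyl on a saturated chain carbon bound to a sulfur), and that change gave a number 15.4 percentage points lower from compound 1 to compound 2 (beyond the scatter). Compound 1 and compound 3 differ in their cores, (4-nitrophenyl in place of 3,4-dimethoxyphenyl on a saturated ring carbon), with the step of a number 14.4 percentage points lower from compound 1 to compound 3 (beyond the scatter). Compound 3 and compound 2 stand within the scatter of each other.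

Compound 4 `CC1=C(C(=O)Nc2ccc(F)cc2)C(c2ccc([N+](=O)[O-])cc2)N=C(SCc2cccc(Cl)c2)N1` has not been measured. It differs from compound 3 by 3-chlorophenyl in place of 2-chlorophenyl on a saturated chain carbon bound to a sulfur, the same change that separates compound 1 from compound 2. In this assay, the expected step is a number 10.9 percentage points lower from compound 3 to compound 4 (beyond the scatter), resting on the size of a number 15.4 percentage points lower from compound 1 to compound 2 (beyond the scatter). Compound 3 starts from 15.9%. Compound 4 is therefore expected to land near 5%, somewhere between -5% and 18%.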

Compound 4, a percentage reported as inhibition, in the whole organism at one dose (the size of the read-out at that dose, not a potency): 15.9%
Compound 4: middle estimate off by 10.9 percentage points, on the low side, within the range that was stated.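

In this assay the new step is no change at the digits printed from compound 3 to compound 4 (within the scatter), so the chlorine shift that mattered on the core of compound 1 did not repeat on the core of compound 3: the same change on two cores in this assay, a number 15.4 percentage points lower (beyond the scatter) from compound 1 to compound 2 and no change at the digits printed (within the scatter) from compound 3 to compound 4, 15.4 percentage points apart, beyond the scatter of two such steps. Read the other way, the change from 3,4-dimethoxyphenyl to 4-nitrophenyl gives a number 1 percentage points higher from compound 2 to compound 4 (within the scatter), so that step also depends on which chlorophenyl group is present: the same change on two cores in this assay, a number 14.4 percentage points lower (beyond the scatter) from compound 1 to compound 3 and a number 1 percentage points higher (within the scatter) from compound 2 to compound 4, 15.4 percentage points apart, beyond the scatter of two such steps. This change therefore cannot be carried between these two cores as a fixed step, but two pairs do not show why, or how it would behave on a third core.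

The compounds shown leave open what a plain phenyl or a pyridine ring would give on a saturated chain carbon bound to a sulfur. They also leave open whether the same picture would hold at other doses.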